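The compounds below may be only part of what the source reports. "The series", "measured", "known", "first", "only" and "open" are said of these compounds alone.

Compound 1 `COC(=O)c1c(-c2cc(OC)cc(OC)c2)oc2ccccc2c1=O`: 6.99 ug/mL
Compound 2 `COc1cc(OC)cc(-c2oc3ccccc3c(=O)c2C(=O)O)c1`: > 25 ug/mL
Compound 3 `COc1cc(-c2cc(=O)c3ccc(O)cc3o2)cc(OC)c1OC`: > 25 ug/mL

Of the compounds shown here, three have so far been tested in a functional assay on HT-29 cells (Homo sapiens) for cytotoxicity, read by MTT assay, with a stated time of 6 days; on this read-out higher numbers stand for an effect only at larger amounts of compound and lower numbers for an effect already at smaller amounts. Compound 1 gives 6.99 ug/mL. For compound 2 the assay reports only a limit, > 25 ug/mL. For compound 3 the assay likewise reports only a limit, > 25 ug/mL. So two of the three results stand at the limit of > 25 ug/mL in this assay, at which 2 of the 3 values shown sit.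

Compound 1 and compound 2 share a core and differ in one place: methyl in place of hydrogen on an oxygen next to a carbonyl group. This change made a step of an at least 3.5-fold lower number from compound 2 to compound 1 (0.55 log units; beyond the scatter).

Compound 4 `COc1ccc2c(=O)cc(-c3cc(OC)c(OC)c(OC)c3)oc2c1` has not yet been measured. It comes from compound 3 by methyl in place of hydrogen on an oxygen on an aromatic ring. The difference between the core of compound 3 and the core of compound 2 is not broken down here. Among the compounds with values here, the change from compound 3 to compound 4 is the same kind of change as the one from compound 2 to compound 1, a methyl in place of a hydrogen on an oxygen, but it is not the same change: in the first pair the oxygen is next to a carbonyl group whose other neighbours are carbonyl carbon, in the second pair it is on an aromatic ring whose other neighbours are aromatic carbon.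

The expected step of an at least 1.3-fold lower number from compound 3 to compound 4 (0.14 log units; that floor lies within the scatter) is smaller and less certain than the measured one, resting on the limit for compound 3 > 25 ug/mL together with the step of an at least 3.5-fold lower number from compound 2 to compound 1 (0.55 log units; beyond the scatter). In this assay compound 4 is therefore estimated at 18 ug/mL, expected to fall between 5 ug/mL and 50 ug/mL.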

Compound 4, concentration for half-maximal effect: > 25 ug/mL
Compound 4 ended at the assay's limit (the forecaster's own chance of this, stated with the estimate: 45%); middle value at least 1.3-fold (0.14 log units) away from the limit.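

In this assay, compound 3 and compound 4 both end at the same limit, so no step between them can be read, and the change from hydroxy to methoxy stays without a size: the limit of > 25 ug/mL in this assay, at which 3 of the 4 values shown sit.

The compounds shown leave open what amounts compound 3 and compound 4 would need for a half-maximal effect, and whether this change shifts that amount at all.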